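Hydroxy on the fused ring of a hydroxamate HDAC6 inhibitor

The source may hold more compounds than are shown below. What is called first, only, known or untested is meant among the compounds shown, and "the series" means these compounds.

Measured compounds:
compound 1, `O=C(CCCCn1[se]c2ccccc2c1=O)NO`, 356 nM
compound 2, `O=C(NO)c1ccc(Cn2[se]c3ccccc3c2=O)cc1`, 37 nM

Of the compounds shown here, two have been measured in an assay on isolated protein for inhibition of protein deacetylase HDAC6 (Homo sapiens), read by fluorescence, with stated times of 15 min and 30 min; on this read-out lower numbers stand for stronger inhibition and higher numbers for weaker inhibition. Compound 1 gives 356 nM, and compound 2 gives 37 nM. Compound 2 stands lowest of the two numbers; the nearest value, that of compound 1, is a higher number, beyond the scatter. For the measured compounds named here, the two compounds differ in more than one place, so no step between them is computed here.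

Compound 3, `O=C(NO)c1ccc(Cn2[se]c3ccc(O)cc3c2=O)cc1`, is the compound to be measured. It differs from compound 2 by hydroxy in place of hydrogen on an aromatic carbon. Going by the values given here, no measured pair shows what this change does in this assay, so its direction is unknown, and the step is expected to lie within the scatter. Compound 3 is therefore estimated at 40 nM, between 15 nM and 120 nM, a step of a 1.1-fold higher number from compound 2 to compound 3 (0.03 log units; within the scatter).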

Compound 3, half-maximal inhibitory concentration: 188 nM
Beside the measured number, compound 3's estimate is 4.7-fold (0.67 log units) below it; the measured number lies above the stated range.
By their numbers in this assay, from the lowest: compound 2; then compounds 3 and 1 (each within the scatter of the next).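

In this assay, for the compounds shown here, the one pair differing in a single place shows that this aromatic carbon of the fused system does not tolerate every change: hydroxy in place of hydrogen weakens inhibition (a 5.1-fold higher number from compound 2 to compound 3 (0.71 log units; beyond the scatter)). The step lies beyond the scatter, yet it is modest, so inhibition is reduced but not lost with this group on the core of compound 2. Nothing at hand accounts for this step, and it rests on a single pair.

From the compounds shown here alone, whether the loss belongs to hydroxy itself or would follow any group on this carbon stays open, and methoxy, fluorine or an amine in the same place would help to tell these apart. Also open, going by these compounds, is whether hydroxy would give a similar step on the core of compound 1, with its open chain.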